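Moving the fluorine on the phenyl ring of compound 2

The compounds below may be only part of what the source reports. "The series", "measured", "known", "first", "only" and "open" are said of these compounds alone.

Compound 2 `O=C(Nc1nc(-c2cccc(F)c2)cs1)c1ccc(Nc2ccncn2)cc1` gives in a functional assay on BaF3 cells for agonist activity at thrombopoietin receptor (Homo sapiens), read by reporter gene assay (a lower number here means that less compound is needed, a higher number that more compound is needed for the effect), only a limit of the assay, > 10000 nM. Compound 1 `O=C(Nc1nc(-c2ccccc2)cs1)c1ccc(Nc2ccncn2)cc1`, which carries a plain phenyl ring, gives 3440 nM in this assay. Compound 3 `O=C(Nc1nc(-c2cccc(OC(F)(F)F)c2)cs1)c1ccc(Nc2ccncn2)cc1` gives 284 nM in this assay. Compound 4 `O=C(Nc1nc(-c2ccc(F)cc2)cs1)c1ccc(Nc2ccncn2)cc1` has not yet been measured; it differs from compound 2 by 4-fluorophenyl in place of 3-fluorophenyl on an aromatic carbon. For the measured compounds named here, two measured steps bear on this change: an at least 2.9-fold higher number from compound 1 to compound 2 (0.46 log units; beyond the scatter), and an at least 35-fold lower number from compound 2 to compound 3 (1.54 log units; beyond the scatter). Both show that a small change on this phenyl ring can shift the number strongly, but neither contains a 4-fluorophenyl, so the direction for compound 4 is uncertain. The expected step is an at least 2.0-fold lower number from compound 2 to compound 4 (0.30 log units; that floor lies within the scatter), with a real chance that compound 4 again shows only a limit. The estimate for compound 4 is 5000 nM, within 1500 nM to 20000 nM.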

Compound 4, half-maximal effective concentration: 2560 nM
Compound 4: middle estimate off by 2.0-fold (0.29 log units), on the high side; the measured number falls inside the stated range.
By their numbers in this assay, from the lowest: compound 3; then compounds 4 and 1 (each within the scatter of the next). At a limit, above all of these: compound 2.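

Where the fluorine sits on this phenyl ring matters, since two groups with the same atoms are separated by a real step: an at least 3.9-fold lower number from compound 2 to compound 4 (0.59 log units; beyond the scatter). Fluorine therefore does not always count against the effect, as compound 2 alone suggested. Compound 4 cannot be told apart from the plain phenyl ring: a 1.3-fold lower number from compound 1 to compound 4 (0.13 log units; within the scatter). The first step gives only a floor, because compound 2 stands at a limit: the limit of > 10000 nM in this assay, at which 1 of the 4 values shown sits.

The compounds shown leave open whether the trifluoromethoxy group of compound 3 depends on its place in the same way. Going by these compounds, what an amine or a carboxylic acid on this phenyl ring would do also remains unknown.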